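A few compounds are considered here, and "the series" means these few. Any claim that something is new, unique, unknown or untested is made for them only; others in the source may bear on it.

Measured compounds:
- compound 1, `O=C(Nc1ccccc1)Nc1cccc(NC(=O)c2ccccn2)c1`, 5190 nM
- compound 2, `O=C(Nc1cccc(Cl)c1)Nc1cccc(NC(=O)c2ccccn2)c1`, 2850 nM

In a functional assay on A549 cells (Homo sapiens) for antiproliferative activity, read by MTT assay, with a stated time of 48 h (a higher number here means a weaker inhibitor, a lower number a stronger inhibitor), compound 1 gives 5190 nM, the highest of the two numbers recorded. Its nearest neighbour is compound 2, which in this assay gives 2850 nM; the step of a 1.8-fold lower number from compound 1 to compound 2 (0.26 log units; within the scatter) stays within the scatter of repeated measurements, so the two compounds cannot be told apart on these numbers.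

Compound 3, `Cc1ccc(NC(=O)Nc2cccc(NC(=O)c3ccccn3)c2)cc1`, has not yet been measured. It differs from compound 1 by methyl in place of hydrogen on an aromatic carbon. For the measured compounds named here, the only measured step that bears on this change is the one from compound 1 to compound 2, where a single small substituent entered the same outer ring and the number moved by a 1.8-fold lower number from compound 1 to compound 2 (0.26 log units; within the scatter), that is, not beyond the scatter. A single methyl is expected to behave similarly, giving at most a modest lowering in this assay.

Compound 3 is therefore estimated at 4000 nM, with a likely range from 1800 nM to 9000 nM, which corresponds to an expected step of a 1.3-fold lower number from compound 1 to compound 3 (0.11 log units; within the scatter).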

Compound 3, half-maximal inhibitory concentration: 20 nM
Compound 3: the middle estimate sits 200-fold (2.30 log units) above what was measured; the whole stated range lies above it.
By their numbers in this assay, from the lowest: compound 3; then compounds 2 and 1 (each within the scatter of the next).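

Placing one methyl on the phenyl group of compound 1, para to a large group, gives a 260-fold lower number from compound 1 to compound 3 (2.41 log units; beyond the scatter) in this assay, so a single added carbon at this position can change the number enormously. Replacing 3-chlorophenyl with 4-methylphenyl gives a 140-fold lower number from compound 2 to compound 3 (2.15 log units; beyond the scatter), but this step changes both the substituent and its place on the ring, so it cannot show which of the two matters. Nothing available here explains the size of these steps.

A chloro at the position of the methyl in compound 3, or a methyl at the position of the chloro in compound 2, would be needed to separate those two effects. From the compounds shown here alone, whether a longer chain such as ethyl, or a methoxy or an amine, at the position of the methyl would keep so low a number also remains open.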